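The source may report more compounds than this note shows. Statements on the series, on what has been measured and on what is new or still open speak of the compounds shown alone.

For the measured compounds named here, compound 1, whose structure is `Cn1cnnc1SCC(=O)N/N=c1/scc(-c2ccc(C#N)cc2)n1-c1ccccc1`, is the only member of this series with a recorded result. In a functional assay on C6 cells (Rattus norvegicus) for cytotoxicity, read by MTT assay, with a stated time of 24 h (on this read-out higher numbers stand for weaker inhibition and lower numbers for stronger inhibition), compound 1 gives > 200 ug/mL, and this value is a limit of the assay rather than a number. The only fixed point in the data is therefore (the limit of > 200 ug/mL in this assay, at which 1 of the 2 values shown sits), so compound 1 stands at the edge of what the test could resolve. A second compound, compound 2 with structure `COc1ccc(-c2cs/c(=N/NC(=O)CSc3nncn3C)n2-c2ccccc2)cc1`, has no result in this assay and is recorded as "not determined" (no result reported).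

The compound still to be tested is compound 3, with structure `N#Cc1ccc(-c2cs/c(=N/NC(=O)CSc3nnnn3-c3ccccc3)n2-c2ccccc2)cc1`. Its difference from compound 1 is 1-phenyl-1H-tetrazol-5-yl in place of 4-methyl-4H-1,2,4-triazol-3-yl on a sulfur. Going by the values given here, with no measured step available between any two compounds, the step in this assay from compound 1 to compound 3 is expected to be none beyond the scatter, as a number no higher from compound 1 to compound 3 (the limit leaves the size open) expresses. The estimate for compound 3 is accordingly 200 ug/mL, with a range from 100 ug/mL to 400 ug/mL, and most likely the assay again returns only a limit.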

Compound 3, half-maximal inhibitory concentration: > 200 ug/mL
Compound 3 gave a limit, no number; the forecaster's own chance of this, stated with the estimate: 70%; the middle value sits exactly at the limit.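

No step from compound 1 to compound 3 can be read in this assay, because both results are limits of the assay: the limit of > 200 ug/mL in this assay, at which 2 of the 3 values shown sit.

The compounds shown leave open whether 1-phenyl-1H-tetrazol-5-yl in place of 4-methyl-4H-1,2,4-triazol-3-yl on a sulfur changes the read-out at all.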